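Cytotoxicity notes: methoxy for methyl on the anilide core

The source may hold more compounds than are shown below. What is called first, only, known or untested is meant among the compounds shown, and "the series" means these compounds.

Compound 1 `Cc1cc(NC(=O)c2ccc(Cl)cc2)ccc1NS(C)(=O)=O` gives 50300 nM in an ADME assay on HEK293 cells (Homo sapiens) for cytotoxicity, read by MTT assay, with a stated time of 48 h; on this read-out higher numbers stand for weaker inhibition and lower numbers for stronger inhibition. Compound 2 `Cc1cc(NC(=O)c2ccc(Cl)c([N+](=O)[O-])c2)ccc1NS(C)(=O)=O` gives 73100 nM in this assay, and compound 3 `CCS(=O)(=O)Nc1ccc(NC(=O)c2ccc(Cl)c([N+](=O)[O-])c2)cc1C` gives 144000 nM. Compound 2 stands second highest of the three numbers, with compound 1 nearest and compound 3 furthest. The two known steps, a 1.5-fold higher number from compound 1 to compound 2 (0.16 log units; within the scatter) and a 2.0-fold higher number from compound 2 to compound 3 (0.29 log units; within the scatter), both stay within the scatter. Compound 4 `COc1cc(NC(=O)c2ccc(Cl)c([N+](=O)[O-])c2)ccc1NS(C)(=O)=O` differs from compound 2 by methoxy in place of methyl on an aromatic carbon. Neither measured step touches this group; both concern other parts of the shared core and both were within the scatter, so no step beyond the scatter is expected for a 1.0-fold lower number from compound 2 to compound 4 (0.00 log units; within the scatter) in this assay. Compound 4 is accordingly estimated at 73000 nM, with a range from 35000 nM to 150000 nM.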

Compound 4, half-maximal inhibitory concentration: 164000 nM
Estimate against measurement, compound 4: 2.2-fold (0.35 log units) below, and the stated range ends below it.
By their numbers in this assay, from the lowest: compounds 1, 2, 3 and 4 (each within the scatter of the next, the first and the last beyond it).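

Methoxy in place of methyl, on the aromatic carbon ortho to a methanesulfonamido group, gives a 2.2-fold higher number from compound 2 to compound 4 (0.35 log units; beyond the scatter) in this assay and is the first single change in the series to pass beyond the scatter, if only modestly. This position therefore affects the read-out, whereas the two earlier steps, made elsewhere on the shared core, stayed within the scatter. No measurement on hand accounts for the step.

Open, as far as these compounds go, is whether a hydroxy, ethoxy or amine group at this carbon would give a similar step. Also open, from the compounds shown here alone, is whether methoxy would act the same way on the core of compound 1 or compound 3.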